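Replacing 4-methoxyphenyl with 2-methyl-1,3-thiazol-4-yl

The source may hold more compounds than are shown below. What is called first, only, known or untested is meant among the compounds shown, and "the series" means these compounds.

In a functional assay on HCT-116 cells (Homo sapiens) for cytotoxicity, read by CellTiter-Glo, with a stated time of 5 days (a higher number here means a weaker inhibitor, a lower number a stronger inhibitor), compound 1 `COc1ccc(Cn2nc(Nc3cc(C)[nH]n3)c3ccccc3c2=O)cc1` gives 1200 nM, the middle of three numbers. Compound 2 `Cc1cc(Nc2nn(Cc3cc(F)ccc3F)c(=O)c3ccccc23)n[nH]1` gives 570 nM, and compound 3 `Cc1cc(Nc2nn(Cc3ccncc3)c(=O)c3ccccc23)n[nH]1` gives 20200 nM. Compound 4 `Cc1cc(Nc2nn(Cc3csc(C)n3)c(=O)c3ccccc23)n[nH]1`, not yet measured, places 2-methyl-1,3-thiazol-4-yl where compound 1 has 4-methoxyphenyl, on a saturated chain carbon bound to an aromatic nitrogen: 2-methyl-1,3-thiazol-4-yl in place of 4-methoxyphenyl on a saturated chain carbon bound to an aromatic nitrogen. Two measured changes at this place bear on it: 2,5-difluorophenyl gave the modest 2.1-fold lower number from compound 1 to compound 2 (0.32 log units; beyond the scatter), while pyridin-4-yl gave the large 17-fold higher number from compound 1 to compound 3 (1.23 log units; beyond the scatter). Like compound 3, compound 4 carries a hetero atom in its aromatic ring, so a moderate rise, smaller than that one, is expected: a 2.5-fold higher number from compound 1 to compound 4 (0.40 log units; beyond the scatter). For compound 4 the estimated value is 3000 nM, with an expected range of 800 nM to 11000 nM.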

Compound 4, half-maximal inhibitory concentration: 4180 nM
Compound 4: middle estimate off by 1.4-fold (0.14 log units), on the low side; the range from low to high includes it.
By their numbers in this assay, from the lowest: compound 2; then compound 1; then compound 4; then compound 3.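

In this assay, 2-methyl-1,3-thiazol-4-yl lands inside the span already set at this position: it costs less than pyridin-4-yl (a 4.8-fold lower number from compound 3 to compound 4 (0.68 log units; beyond the scatter)) but still loses to 4-methoxyphenyl (a 3.5-fold higher number from compound 1 to compound 4 (0.54 log units; beyond the scatter)) and to 2,5-difluorophenyl (a 7.3-fold higher number from compound 2 to compound 4 (0.87 log units; beyond the scatter)). So among these four compounds, the two rings with hetero atoms, in compound 3 and compound 4, both give higher numbers than the two carbon-only rings, but by clearly different amounts. Nothing available explains this order. From the compounds shown here alone, what an amine or a carboxylic acid would do at this place remains open, as does the effect of a longer chain in place of the saturated chain carbon.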